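A Cyclic Amine Replaces Diethylamino on the Ether Chain

The source may hold more compounds than are shown below. What is called first, only, known or untested is meant among the compounds shown, and "the series" means these compounds.

Of the compounds shown here, two have been measured in an assay on cerebellum for displacement of a labelled ligand from histamine H1 receptor (Cavia porcellus), read by scintillation counting, with a stated time of 60 min; a higher number here means a weaker inhibitor, a lower number a stronger inhibitor. Compound 1 `CCN1CCN(CCCOc2ccc3c(c2)C(=O)N(C)CC3)CC1` carries a 4-ethylpiperazin-1-yl group on the ether chain and gives 1100 nM. Compound 2 `CCN(CC)CCCOc1ccc2c(c1)C(=O)N(C)CC2` carries a diethylamino group at the same place and gives 542 nM. Within the data shown here, the single step between them, a 2.0-fold lower number from compound 1 to compound 2 (0.31 log units; beyond the scatter), shows that opening the ring into two ethyl arms lowered the number. Among the measured compounds shown here, on these two numbers compound 2 stands lowest, with compound 1 the only neighbour and a modest step away.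

Compound 3 `CN1CCc2ccc(OCCCN3CCC(=O)CC3)cc2C1=O` is the next step: 4-oxopiperidin-1-yl in place of diethylamino on a saturated chain carbon, three bonds along the chain from an oxygen on an aromatic ring. For the measured compounds named here, the one measured step that bears on this change is the one from compound 1 to compound 2, where a six-membered ring amine was exchanged for diethylamino; compound 3 goes the other way, back to a six-membered ring amine, though a different one. That step was modest in size, so a modest step in this assay is expected here too, toward a higher number. Compound 3 is estimated to give 1500 nM, within a range from 500 nM to 4500 nM. This expectation corresponds to a step of a 2.8-fold higher number from compound 2 to compound 3 (0.44 log units; beyond the scatter).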

Compound 3, inhibition constant: 176 nM
Estimate against measurement, compound 3: 8.5-fold (0.93 log units) above; measured number outside the range, below it.
By their numbers in this assay, from the lowest: compound 3; then compound 2; then compound 1.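

A ring on the ether chain is therefore no drawback in itself: 4-oxopiperidin-1-yl in place of diethylamino brings a 3.1-fold lower number from compound 2 to compound 3 (0.49 log units; beyond the scatter) in this assay and so runs against the direction that compound 1 alone had suggested for a ring amine. The two ring amines also differ clearly from each other, with a 6.3-fold lower number from compound 1 to compound 3 (0.80 log units; beyond the scatter) on exchanging 4-ethylpiperazin-1-yl for 4-oxopiperidin-1-yl, so among these three compounds the outcome at this position depends on which ring is attached and not simply on whether a ring is present. Nothing available here explains why the ring in compound 3 gives the lowest number of the three.

The compounds shown leave open whether the carbonyl of the 4-oxopiperidin-1-yl group matters or whether the ring alone would give a similar number, a question that a plain piperidin-1-yl group or a 4-hydroxypiperidin-1-yl group could help to settle. They also leave open whether a morpholin-4-yl group would behave in the same way, and whether this order of the three amines would hold on a longer chain.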